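A Second Cyclopentylamino Group and Cytotoxicity

The compounds below may be only part of what the source reports. "The series", "measured", "known", "first", "only" and "open" are said of these compounds alone.

Compound 1, `Fc1ccc(-c2nn3c(NC4CCCC4)cccc3c2-c2ccnc(NC3CCCC3)n2)cc1`, and compound 2, `Fc1ccc(-c2nn3ccc(NC4CCCC4)cc3c2-c2ccnc(NC3CCCC3)n2)cc1`, share a core and differ in where a cyclopentylamino group sits. In an ADME assay on Vero cells (Chlorocebus sabaeus) for cytotoxicity (on this read-out lower numbers stand for higher toxicity in this test and higher numbers for lower toxicity in this test), compound 1 gives only a limit of > 160000 nM, not a number. In this assay, within the data shown here, compound 2 gives 18000 nM, which is the only numeric value on hand. The other result, that of compound 1, is the limit of > 160000 nM in this assay, at which 1 of the 2 values shown sits. Compound 3, `Fc1ccc(-c2nn3c(NC4CCCC4)cc(NC4CCCC4)cc3c2-c2ccnc(NC3CCCC3)n2)cc1`, is not yet measured. It differs from compound 2 by cyclopentylamino in place of hydrogen on an aromatic carbon. Among the measured compounds shown here, with no measured pair showing the effect of such an added group, the expectation for compound 3 leans on compound 2 and the limit of compound 1 alone. The expected step in this assay is a 1.4-fold higher number from compound 2 to compound 3 (0.14 log units; within the scatter), a change not expected to exceed the usual scatter. Compound 3 is therefore estimated at 25000 nM, within a range from 6000 nM to 160000 nM.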

Compound 3, half-maximal cytotoxic concentration: > 40000 nM
Compound 3 gave a limit, no number; the forecaster's own chance of this, stated with the estimate: 25%; middle value at least 1.6-fold (0.20 log units) from the limit.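

In this assay, putting cyclopentylamino in place of hydrogen on an aromatic carbon next to the ring nitrogen gives an at least 2.2-fold higher number from compound 2 to compound 3 (0.34 log units; beyond the scatter). Among these compounds, this is the first measured pair to show the effect of this change at this position, and it goes towards lower toxicity in this test, not higher. From the compounds shown here alone, the true size of the step remains open, since compound 3 gives a limit and not a number: the limit of > 40000 nM in this assay, at which 1 of the 3 values shown sits. The step from compound 1 to compound 3 cannot be read, as both of its ends are limits.

A single pair cannot show which part of the cyclopentylamino group matters, so a plain amine, a methyl group or a carboxylic acid on this same carbon remains an open comparison. These compounds also do not show why the number rises.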